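Swapping the amine arm at the para position

The compounds below may be only part of what the source reports. "The series", "measured", "known", "first", "only" and "open" are said of these compounds alone.

Compound 1 `CN(CCCN1CCCCC1)c1cccc(C(=O)N2CCc3ccc(OS(N)(=O)=O)cc3C2)c1`: 30.6%
Compound 2 `CCCN(Cc1ccccc1)c1cccc(C(=O)N2CCc3ccc(OS(N)(=O)=O)cc3C2)c1`: 67.4%
Compound 3 `CCCN(Cc1ccccc1)c1ccc(C(=O)N2CCc3ccc(OS(N)(=O)=O)cc3C2)cc1`: 94.3%

In an assay on HEK293 cells for inhibition of Steryl-sulfatase (Homo sapiens), tested at 1 uM (on this read-out lower numbers stand for a weaker effect and higher numbers for a stronger effect at the one concentration tested), compound 3 gives 94.3%, compound 2 gives 67.4% and compound 1 gives 30.6%. Compounds 2 and 3 share the same atoms joined differently; how their cores differ is not broken down here. Compound 1 differs from compound 2 by methyl(3-(piperidin-1-yl)propyl)amino in place of benzyl(propyl)amino on an aromatic carbon, and that step was a number 36.8 percentage points lower from compound 2 to compound 1 (beyond the scatter). Compound 4 `CN(CCCN1CCCCC1)c1ccc(C(=O)N2CCc3ccc(OS(N)(=O)=O)cc3C2)cc1` is not yet measured; it differs from compound 3 by methyl(3-(piperidin-1-yl)propyl)amino in place of benzyl(propyl)amino on an aromatic carbon, the same kind of change, though here the place is para to a large group rather than meta to a large group. Because the earlier step was a number 36.8 percentage points lower from compound 2 to compound 1 (beyond the scatter), a loss of similar size is expected from compound 3 to compound 4, namely a number 36.3 percentage points lower from compound 3 to compound 4 (beyond the scatter). Compound 4 is therefore estimated at 58%, within about 35% to 80% in this assay.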

Compound 4, a percentage reported as inhibition, at one concentration (the size of the read-out at that concentration, not a potency) in the Steryl-sulfatase assay: 40.7%
Compound 4: middle estimate off by 17.3 percentage points, on the high side, within the range that was stated.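

In the Steryl-sulfatase assay compound 4 gives 40.7%. In the Steryl-sulfatase assay, methyl(3-(piperidin-1-yl)propyl)amino in place of benzyl(propyl)amino again lowers the read-out, with a number 53.6 percentage points lower from compound 3 to compound 4 (beyond the scatter). The direction of the change carries from one core to the other, but its size does not: the same change on two cores in the Steryl-sulfatase assay, a number 36.8 percentage points lower (beyond the scatter) from compound 2 to compound 1 and a number 53.6 percentage points lower (beyond the scatter) from compound 3 to compound 4, 16.8 percentage points apart, beyond the scatter of two such steps

In a physicochemical assay for lipophilicity (on this read-out higher numbers stand for higher lipophilicity and lower numbers for lower lipophilicity), compound 3 gives 1.93 and compound 4 gives 1.93. In the physicochemical assay the same swap shows no change at the digits printed from compound 3 to compound 4 (within the scatter), yet two cores are too few to show why the size differs or to predict the step on a third core.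

Each swap also replaces the whole arm at once, leaving open whether the loss follows the departing benzyl ring or the entering piperidine ring. A morpholine ring or a dimethylamino group at the end of the propyl chain could help separate the two.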